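This account rests on a few compounds, and the source may have more. Where it says the series, first, only, none or still open, it means among the compounds named here.

Of the compounds shown here, two of this small series have been measured. Compound 1 `CCCCNc1ccnc2cc(F)ccc12` gives in a functional assay on MDA-MB-468 cells (Homo sapiens) for cytotoxicity, read by sulforhodamine B assay, with a stated time of 48 h, in the presence of a further agent that is not named here (on this read-out lower numbers stand for stronger inhibition of growth and higher numbers for weaker inhibition of growth), a value of 1440 nM. Compound 2 `CN(C)CCNc1ccnc2cc(Cl)ccc12` gives in this assay a value of 3240 nM. Of the two numbers, compound 2 stands at the higher one, and its gap to compound 1 lies beyond the usual scatter of repeated measurements. Within the data shown here, the two compounds differ from each other in more than one place, so their values show only that compound 2 sits higher than compound 1, not what either difference contributes on its own.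

Compound 3 `CN(C)CCNc1ccnc2cc(F)ccc12` has not yet been measured. It is reached from compound 2 by a single change: fluoro in place of chloro on an aromatic carbon. Among the measured compounds shown here, no measured pair isolates this change, so there is no measured step to lean on. The dimethylaminoethylamino chain of compound 2 is kept, and only the halogen is exchanged. The step expected in this assay is a 1.3-fold lower number from compound 2 to compound 3 (0.11 log units; within the scatter), a modest move toward a lower number at most, and possibly none beyond the scatter. Compound 3 is accordingly expected to give about 2500 nM in this assay, within a range from 1200 nM to 5500 nM.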

Compound 3, concentration for 50% growth inhibition: 4610 nM
The estimate for compound 3 lay 1.8-fold (0.27 log units) below the measured number; low and high end bracket the measured number.
By their numbers in this assay, from the lowest: compound 1; then compounds 2 and 3 (each within the scatter of the next).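

In this assay, the exchange of chloro for fluoro on this aromatic carbon, taken alone, gives a 1.4-fold higher number from compound 2 to compound 3 (0.15 log units; within the scatter) and so, with the dimethylaminoethylamino chain kept, the two halogens cannot be told apart at this position. Among these compounds, with fluoro held constant, the chain can now be read on its own for the first time: dimethylamino in place of ethyl on the saturated chain carbon gives a 3.2-fold higher number from compound 1 to compound 3 (0.51 log units; beyond the scatter) and is, though modest, the only single change here that lies beyond the scatter. Nothing available here explains either step.

As far as these compounds go, whether chloro and fluoro also stay this close on the chain of compound 1 remains open, as does how a hydrogen, a methoxy or a trifluoromethyl group would read on the same aromatic carbon. On the chain side, the compounds shown leave open how a diethylamino group, a piperidine or a longer chain ending in dimethylamino would read, and whether the step from ethyl to dimethylamino holds with chloro on the core.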